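The source may hold more compounds than are shown below. What is called first, only, known or untested is meant among the compounds shown, and "the series" means these compounds.

Measured in a functional assay on CAL-27 cells (Homo sapiens) for antiproliferative activity, read by MTT assay, with a stated time of 72 h; on this read-out lower numbers stand for stronger inhibition and higher numbers for weaker inhibition:
Compound 1 `CCNC(=O)NOCc1ccc(/C=C/C(=O)NO)cc1`: 14000 nM
Compound 2 `O=C(/C=C/c1ccc(CONC(=O)Nc2ccccc2)cc1)NO`: 62000 nM

Compound 2 has the higher of the two numbers, so it is the weaker inhibitor of the pair. Compound 3 `Cc1cc(C)cc(NC(=O)NOCc2ccc(/C=C/C(=O)NO)cc2)c1` carries 3,5-dimethylphenyl in place of phenyl on an amide-type nitrogen. Among the measured compounds shown here, one measured step bears on this change, a modest one at the same nitrogen: a 4.4-fold higher number from compound 1 to compound 2 (0.65 log units; beyond the scatter). For the measured compounds named here, that step replaces ethyl with phenyl, and no measured step adds groups to the phenyl. No clear direction follows, so no change beyond the scatter is expected in this assay. The expected step is a 1.1-fold higher number from compound 2 to compound 3 (0.05 log units; within the scatter). For compound 3 the estimated value is 70000 nM, with an expected range of 22000 nM to 200000 nM.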

Compound 3, half-maximal inhibitory concentration: 2270 nM
Compound 3: the middle estimate sits 31-fold (1.49 log units) above what was measured, and the stated range ends above it.
By their numbers in this assay, from the lowest: compound 3; then compound 1; then compound 2.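

In this assay, adding the two methyl groups of 3,5-dimethylphenyl to the phenyl on this amide-type nitrogen gives a large gain (a 27-fold lower number from compound 2 to compound 3 (1.44 log units; beyond the scatter)), so substituents on this ring matter far more than compound 2 alone suggested. The same group also improves on ethyl (a 6.2-fold lower number from compound 1 to compound 3 (0.79 log units; beyond the scatter)), so an aromatic ring at this nitrogen is not in itself a drawback. Nothing shown here gives a reason for these shifts. Going by these compounds, whether both methyl groups are needed stays open, as does the effect of other ring substituents, such as chlorine, methoxy or an amine.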